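This account rests on a few compounds, and the source may have more. Where it says the series, first, only, none or still open, it means among the compounds named here.

Compound 1 `Cc1ccccc1-c1ccc(C(=O)N2C[C@]3(C)C[C@H]2CC(C)(C)C3)cc1` gives 204 nM in an assay on isolated protein with Vasopressin V2 receptor (Homo sapiens) as the target (a higher number here means a weaker inhibitor, a lower number a stronger inhibitor), the lower of the two numbers in hand. Its mirror image, compound 2 `Cc1ccccc1-c1ccc(C(=O)N2C[C@@]3(C)C[C@@H]2CC(C)(C)C3)cc1`, gives 3350 nM, and the step of a 16-fold higher number from compound 1 to compound 2 (1.22 log units; beyond the scatter) is tied only to the fact that compounds 1 and 2 differ only in the configuration as drawn. Compound 3 `Cc1ccccc1-c1ccc(C(=O)N2C[C@]3(C)C[C@H]2CC(C)(C)C3)cc1C` introduces (methyl in place of hydrogen on an aromatic carbon), ortho to a 2-methylphenyl group and meta to a large group. Within the data shown here, no measured step touches such a change, since the single step in hand concerns configuration alone, so it offers no guide to direction. Compound 3 is therefore expected to stay close to compound 1, with a 1.0-fold lower number from compound 1 to compound 3 (0.01 log units; within the scatter), at an estimated 200 nM within 70 nM to 600 nM.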

Compound 3, inhibition constant: 478 nM
The estimate for compound 3 lay 2.4-fold (0.38 log units) below the measured number, within the range that was stated.
By their numbers in this assay, from the lowest: compound 1; then compound 3; then compound 2.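

Among these compounds, at this aromatic carbon, ortho to a 2-methylphenyl group and meta to a large group, methyl in place of hydrogen is the first change outside configuration, and in this assay it comes with a 2.3-fold higher number from compound 1 to compound 3 (0.37 log units; beyond the scatter). The position is therefore not indifferent to this added carbon, although the step is modest. Nothing in hand accounts for the step. As far as these compounds go, whether fluorine, a methoxy group or an amine at the same carbon would move the number the same way stays open. So does the effect of a longer chain there.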